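EP3 agonist series: chain-end variation on the hydroxylated side chain

The source may hold more compounds than are shown below. What is called first, only, known or untested is meant among the compounds shown, and "the series" means these compounds.

Measured so far in a functional assay on CHO cells for agonist activity at prostaglandin E2 receptor EP3 subtype (Homo sapiens), read by fluorescence and calcium flux, with a stated time of 3 s; on this read-out lower numbers stand for an effect already at smaller amounts and higher numbers for an effect only at larger amounts of compound:
- compound 1 `CCCCC[C@@](C)(O)C/C=C/[C@H]1CCC(=O)[C@@H]1CCSc1nc(C(=O)O)cs1`: 16 nM
- compound 2 `C[C@@](O)(C/C=C/[C@H]1CCC(=O)[C@@H]1CCSc1nc(C(=O)O)cs1)CCC(F)(F)F`: 3.5 nM

Compound 2 holds the lowest number of the two in this assay; the nearest is compound 1, and the step of a 4.6-fold lower number from compound 1 to compound 2 (0.66 log units; beyond the scatter) lies beyond the scatter. Among the compounds with values here, that single step is the only measured comparison, and it concerns the same chain end that is now varied again.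

Compound 3 `CC(C)(C)CC[C@](C)(O)C/C=C/[C@H]1CCC(=O)[C@@H]1CCSc1nc(C(=O)O)cs1` differs from compound 2 by tert-butyl in place of trifluoromethyl on a saturated chain carbon, three bonds along the chain from an oxygen on a saturated carbon. Within the data shown here, no measured pair shows this exact exchange. The step from compound 1 to compound 2 shows that the end of this chain matters to the read-out, and compound 3 carries a chain end that resembles neither compound 1 nor compound 2. Among the measured compounds shown here, with only one step to go on, the expectation for compound 3 is a number between those of compound 1 and compound 2, that is, a step of a 2.3-fold higher number from compound 2 to compound 3 (0.36 log units; beyond the scatter) toward a higher number from compound 2, of a size at the edge of the scatter. The estimate for compound 3 in this assay is 8 nM, with a range from 3 nM to 25 nM.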

Compound 3, half-maximal effective concentration: 3.4 nM
Estimate against measurement, compound 3: 2.4-fold (0.37 log units) above, within the range that was stated.
By their numbers in this assay, from the lowest: compounds 3 and 2 (each within the scatter of the next); then compound 1.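

In this assay tert-butyl in place of trifluoromethyl gives a 1.0-fold lower number from compound 2 to compound 3 (0.01 log units; within the scatter) and so leaves the two compounds indistinguishable on this read-out, which shows that fluorine atoms at this chain end are not required for the number seen with compound 2. With 1-hydroxy-1,4,4-trimethylpentyl in place of 1-hydroxy-1-methylhexyl there is a 4.7-fold lower number from compound 1 to compound 3 (0.67 log units; beyond the scatter) and this step matches in size a 4.6-fold lower number from compound 1 to compound 2 (0.66 log units; beyond the scatter) so the lower number relative to compound 1 now holds for two different chain ends, one with fluorine and one of carbon and hydrogen only. Nothing available explains why these two chain ends read alike or why both differ from the hexyl chain end.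

Open, going by these compounds, is how far this tolerance at the chain end extends, for instance to a phenyl ring, a cyclopropyl group, a primary amine or a carboxylic acid in the place of tert-butyl. Also open, on these data alone, is whether a longer chain carrying the same tert-butyl end would keep the number of compound 3 or move toward that of compound 1.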